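A few compounds are considered here, and "the series" means these few. Any claim that something is new, unique, unknown or untested is made for them only; others in the source may bear on it.

Four close relatives are compared here, all built on the same acetophenone-type core with a benzyl ether arm that carries one small substituent. Compound 1 `CC(=O)c1cccc(OCc2cccc(F)c2)c1` and compound 2 `CC(=O)c1cccc(OCc2ccc(F)cc2)c1` each carry a fluoro group; compound 3 `CC(=O)c1cccc(OCc2cccc(C)c2)c1` and compound 4 `CC(=O)c1cccc(OCc2ccc(C)cc2)c1` each carry a methyl group instead. How compound 2 differs from compound 1 is not broken down here: the two are made of the same atoms joined differently.

The measurement is an assay on isolated protein for inhibition of Amine oxidase [flavin-containing] B (Homo sapiens), read by Amplex Red, with a stated time of 15 min; on this read-out lower numbers stand for stronger inhibition and higher numbers for weaker inhibition. In this assay compound 1 gives 193 nM, compound 3 gives 893 nM, and compound 2 gives 86.4 nM, the lowest of the three numbers.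

Between compound 1 and compound 3 the change is methyl in place of fluoro on an aromatic carbon, and it produced a 4.6-fold higher number from compound 1 to compound 3 (0.67 log units; beyond the scatter). The change from compound 2 to compound 4 is methyl in place of fluoro on an aromatic carbon. The two changes are the same kind of change, but not the same: in the first the group sits meta to a large group, in the second para to a large group.

The expected step from compound 2 to compound 4 is therefore a 4.6-fold higher number from compound 2 to compound 4 (0.67 log units; beyond the scatter), an estimate that rests on the measured move from compound 1 to compound 3 a 4.6-fold higher number from compound 1 to compound 3 (0.67 log units; beyond the scatter) with the same swap of groups. On that basis compound 4 is expected to give about 400 nM, most plausibly between 150 nM and 1100 nM.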

Compound 4, half-maximal inhibitory concentration: 140 nM
Estimate against measurement, compound 4: 2.9-fold (0.46 log units) above; measured number outside the range, below it.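

In this assay, methyl in place of fluoro, para to a large group, gives a 1.6-fold higher number from compound 2 to compound 4 (0.21 log units; within the scatter), so compound 2 and compound 4 cannot be told apart on this read-out. The swap therefore does not carry over at one fixed size, and the difference between the two cases is larger than the scatter of the measurements would explain: the same change on two cores in this assay, a 4.6-fold higher number (0.67 log units; beyond the scatter) from compound 1 to compound 3 and a 1.6-fold higher number (0.21 log units; within the scatter) from compound 2 to compound 4, 2.9-fold (0.46 log units) apart, beyond the scatter of two such steps. Going by these compounds alone, this shows that a step measured on one compound is an unsafe guide to the same swap on a close relative, but with only two pairs it does not show why the steps differ, or how the swap would behave on any other core.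

The compounds shown leave open whether this difference between the two cases is specific to fluoro and methyl, or whether it would also appear with a chloro, methoxy or trifluoromethyl group in the same places. They also leave open what a larger change on the benzyl ether arm, such as an amine or a carboxylic acid, would do to the inhibition.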